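The compounds below may be only part of what the source reports. "The series", "measured", "known", "first", "only" and "open" are said of these compounds alone.

In an ADME assay on 2209-23 cells (Homo sapiens) for cytotoxicity, read by WST assay (on this read-out lower numbers stand for higher toxicity in this test and higher numbers for lower toxicity in this test), compound 1 `CS(=O)(=O)Nc1ccc2c(c1)S(=O)(=O)C=C(c1c(O)c3cc(F)ccc3n(Cc3ccc(F)c(Cl)c3)c1=O)N2` gives > 50000 nM, which is a limit of the assay. Compound 2 `CS(=O)(=O)Nc1ccc2c(c1)S(=O)(=O)C=C(c1c(O)c3cc(F)ccc3n(Cc3ccncc3)c1=O)N2` gives > 50000 nM, also only a limit, and no number is known for it. Compound 3 `COC(C)(C)CCn1c(=O)c(C2=CS(=O)(=O)c3cc(NS(C)(=O)=O)ccc3N2)c(O)c2cc(F)ccc21` carries 2-methoxy-2-methylpropyl in place of pyridin-4-yl on a saturated chain carbon bound to an aromatic nitrogen. Going by the values given here, the one measured step at this place is a step that the two limits leave unreadable from compound 1 to compound 2, so no size can be carried over from it. Among the compounds with values here, the series so far stands at the limit of > 50000 nM in this assay, at which 2 of the 2 values shown sit. A step beyond the scatter is therefore not expected in this assay, and no direction is assigned. The estimated change is a number no higher from compound 2 to compound 3 (the limit leaves the size open). Compound 3 is expected near 50000 nM, with an estimated range of 20000 nM to 100000 nM.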

Compound 3, half-maximal cytotoxic concentration: > 50000 nM
Compound 3 gave a limit, no number (the forecaster's own chance of this, stated with the estimate: 85%); the middle value lies on the limit itself.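

In this assay, going by these compounds alone, the values of compound 1, compound 2 and compound 3 are all limits, so no step among them can be read. The compounds shown leave open where each true value lies and whether any group on this saturated chain carbon bound to an aromatic nitrogen changes it.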